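The source may hold more compounds than are shown below. What is called first, only, known or untested is meant among the compounds shown, and "the series" means these compounds.

Compound 1 `O=C(Nc1ccccc1O)C1CCc2ccccc2N1C(=O)c1ccc(Cl)cc1` carries a hydroxy group on an aromatic carbon of the shared core. In a functional assay on ACHN cells (Homo sapiens) for cytotoxicity, read by sulforhodamine B assay, with a stated time of 72 h (on this read-out higher numbers stand for weaker inhibition of growth and lower numbers for stronger inhibition of growth), compound 1 gives 19600 nM, the highest of the three numbers measured. Compound 2 `O=C(Nc1cc(C(F)(F)F)cc(C(F)(F)F)c1)C1CCc2ccccc2N1C(=O)c1ccc(Cl)cc1` gives 2570 nM, and compound 3 `O=C(Nc1ccccc1C(F)(F)F)C1CCc2ccccc2N1C(=O)c1ccc(Cl)cc1` gives 824 nM. For the measured compounds named here, the single counted step, a 24-fold lower number from compound 1 to compound 3 (1.38 log units; beyond the scatter), alters only that hydroxy group. Compound 4 `O=C(Nc1ccccc1O)C1CCc2ccccc2N1` differs from compound 1 at a different place: hydrogen in place of (4-chlorophenyl)carbonyl on a nitrogen on an aromatic ring in a ring. Going by the values given here, no measured step touches this part of the core, so the expectation rests on the size of the group removed alone and carries wide uncertainty. Compound 4 is expected to inhibit growth more weakly, with a 2.3-fold higher number from compound 1 to compound 4 (0.36 log units; beyond the scatter). Compound 4 is therefore estimated at 45000 nM, within a range from 15000 nM to 150000 nM.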

Compound 4, concentration for 50% growth inhibition: 3990 nM
Estimate against measurement, compound 4: 11-fold (1.05 log units) above; measured number outside the range, below it.
By their numbers in this assay, from the lowest: compound 3; then compounds 2 and 4 (each within the scatter of the next); then compound 1.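

Taking the (4-chlorophenyl)carbonyl off the ring nitrogen is the first change shown at this position, and in this assay the step of a 4.9-fold lower number from compound 1 to compound 4 (0.69 log units; beyond the scatter) shows that growth inhibition does not depend on this large group in compound 1. With hydrogen there, the number is lower, not higher. No measurement available accounts for this step. Going by these compounds, whether a smaller group on this nitrogen, such as acetyl or methyl, would give a lower or higher number remains open. So does whether trifluoromethyl in place of hydroxy would lower the number to a similar extent when this nitrogen carries hydrogen.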